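Three limit values on the shared core; a bromo-hydroxy analogue

This account rests on a few compounds, and the source may have more. Where it says the series, first, only, none or still open, it means among the compounds named here.

Measured compounds:
- Compound 1 `C/C(=N\NC(=O)c1cccc(S(=O)(=O)N2CCOCC2)c1)c1cccc(N)c1` in a functional assay on SMMC-7721 cells (Homo sapiens) for antiproliferative activity, read by MTT assay, with a stated time of 72 h (on this read-out lower numbers stand for stronger inhibition and higher numbers for weaker inhibition), gives > 100000 nM, a limit of the assay.
- Compound 2 `C/C(=N\NC(=O)c1cccc(S(=O)(=O)N2CCOCC2)c1)c1ccc(F)cc1` in this assay gives > 100000 nM, likewise a limit.
- Compound 3 `C/C(=N\NC(=O)c1cccc(S(=O)(=O)N2CCOCC2)c1)c1cc(O)ccc1O` in this assay gives > 100000 nM, again a limit.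

Compound 2 therefore stands at the same limit as the other two; all three values sit together (the limit of > 100000 nM in this assay, at which 3 of the 3 values shown sit). No ordering among compounds 1, 2 and 3 can be read from this.

Compound 4 `C/C(=N\NC(=O)c1cccc(S(=O)(=O)N2CCOCC2)c1)c1cc(Br)ccc1O` differs from compound 2 by 5-bromo-2-hydroxyphenyl in place of 4-fluorophenyl on a carbon with a double bond to nitrogen.

Among the measured compounds shown here, the only measured step on the same position that bears on this change is a step that the two limits leave unreadable from compound 2 to compound 3; the related steps a step that the two limits leave unreadable from compound 1 to compound 2 and a step that the two limits leave unreadable from compound 1 to compound 3 are equally unreadable. For the measured compounds named here, no step in this assay has a readable size, so no direction can be expected beyond the scatter.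

Compound 4 is accordingly expected to give about 100000 nM, with a range from 30000 nM to 300000 nM, most probably reported as a limit again. The expected step is a number no higher from compound 2 to compound 4 (the limit leaves the size open).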

Compound 4, half-maximal inhibitory concentration: 2410 nM
Compound 4: middle estimate off by 41-fold (1.62 log units), on the high side, and the stated range ends above it.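

In this assay, the group on the carbon with a double bond to nitrogen can bring the read-out off the limit, with an at least 41-fold lower number from compound 2 to compound 4 (1.61 log units; beyond the scatter) and an at least 41-fold lower number from compound 1 to compound 4 (1.61 log units; beyond the scatter). The closest comparison is bromo in place of hydroxy on an aromatic carbon, with an at least 41-fold lower number from compound 3 to compound 4 (1.61 log units; beyond the scatter), so the hydroxy that compound 3 and compound 4 share does not give a readable value without the bromo. The steps among compound 1, compound 2 and compound 3 cannot be read, and the sizes of the new steps are only lower bounds: the limit of > 100000 nM in this assay, at which 3 of the 4 values shown sit.

On these data alone, whether the bromo still gives a readable value without the hydroxy remains open. Also open, as far as these compounds go, is whether chloro, iodo or methyl in place of the bromo would do the same, as only compound 4 has a value that is not a limit.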